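The source may report more compounds than this note shows. Statements on the series, on what has been measured and on what is new or still open speak of the compounds shown alone.

Compound 3 `O=C1O[C@@H](Cn2cc(Br)nn2)CN1c1ccc(C2=CCS(=O)(=O)CC2)c(F)c1` gives the lowest of the two numbers obtained so far in an assay for binding affinity to Amine oxidase [flavin-containing] A (Homo sapiens) (on this read-out higher numbers stand for weaker inhibition and lower numbers for stronger inhibition), namely 16000 nM. Compound 1 `O=C1O[C@@H](Cn2cc(CO)nn2)CN1c1ccc(C2=CCS(=O)(=O)CC2)c(F)c1` gives 47000 nM in this assay. Compound 2 `CCc1cn(C[C@H]2CN(c3ccc(C4=CCS(=O)(=O)CC4)c(F)c3)C(=O)O2)nn1` reaches only the limit of this assay, > 200000 nM, and no number. Compound 4 `O=C1O[C@@H](Cn2ccnn2)CN1c1ccc(C2=CCS(=O)(=O)CC2)c(F)c1` differs from compound 3 by hydrogen in place of bromo on an aromatic carbon. Two measured steps lead to the bromo group on that aromatic carbon: a 2.9-fold lower number from compound 1 to compound 3 (0.47 log units; beyond the scatter) and an at least 12-fold lower number from compound 2 to compound 3 (1.09 log units; beyond the scatter). Both point to the bromo group as the change that lowers the number, so removing it is expected to raise the number, by a 3.1-fold higher number from compound 3 to compound 4 (0.49 log units; beyond the scatter). Compound 4 is therefore estimated to give 50000 nM in this assay, within a range from 20000 nM to 150000 nM.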

Compound 4, inhibition constant: 3400 nM
Beside the measured number, compound 4's estimate is 15-fold (1.17 log units) above it; measured number outside the range, below it.
By their numbers in this assay, from the lowest: compound 4; then compound 3; then compound 1. At a limit, above all of these: compound 2.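

In this assay, hydrogen on this aromatic carbon gives the lowest number of the four compounds, with a 4.7-fold lower number from compound 3 to compound 4 (0.67 log units; beyond the scatter) and a 14-fold lower number from compound 1 to compound 4 (1.14 log units; beyond the scatter). Compound 2 stands at a limit, not a number, and still gives an at least 58-fold lower number from compound 2 to compound 4 (1.76 log units; beyond the scatter). The bromo group therefore lowers the number only against hydroxymethyl and ethyl, while each of the three groups gives a higher number than hydrogen.

As far as these compounds go, it stays open whether chloro, fluoro or methyl on this carbon would also raise the number. The same holds for an amine or a carboxylic acid.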